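This account rests on a few compounds, and the source may have more. Where it says the series, first, only, none or still open, it means among the compounds named here.

Measured so far in a functional assay on MCF7 cells (Homo sapiens) for cytotoxicity, read by MTT assay, with a stated time of 72 h; on this read-out higher numbers stand for weaker inhibition and lower numbers for stronger inhibition:
Compound 1 `CN(C)c1ccc(C=C2C(=O)N(c3ccc(Cl)cc3)N(c3ccc(Cl)cc3)C2=O)cc1`: > 128000 nM (a limit of the assay, not a number)
Compound 2 `COc1cc(C=C2C(=O)N(c3ccc(Cl)cc3)N(c3ccc(Cl)cc3)C2=O)cc(OC)c1OC`: 16200 nM
Compound 3 `CC(=C1C(=O)N(c2ccc(Cl)cc2)N(c2ccc(Cl)cc2)C1=O)c1ccc(O)cc1`: 76500 nM

Among these three, only two compounds give actual numbers, and compound 2 has the lower of them. Its number stands clearly apart from that of compound 3, by more than the usual scatter of the measurement, so compound 2 shows the stronger inhibition of the pair.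

Compound 4 `COc1ccc(C=C2C(=O)N(c3ccc(Cl)cc3)N(c3ccc(Cl)cc3)C2=O)cc1OC` keeps the core of compound 2 but has hydrogen in place of methoxy on an aromatic carbon. Within the data shown here, no measured pair isolates this change, so the expectation rests on little. Compound 2, at 16200 nM, carries the methoxy group that is lost, and compound 3, at 76500 nM, carries no methoxy group at all. In this assay, a moderate move towards weaker inhibition is therefore expected, and the estimated change is a 2.5-fold higher number from compound 2 to compound 4 (0.39 log units; beyond the scatter). For compound 4 the estimated value is 40000 nM, with an expected range from 12000 nM to 120000 nM.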

Compound 4, half-maximal inhibitory concentration: > 128000 nM
Compound 4 ended at the assay's limit; the forecaster's own chance of this, stated with the estimate: 20%; at least 3.2-fold (0.50 log units) between middle value and limit.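

In this assay, compound 4 gives > 128000 nM, which is a limit of the assay and not a number. Hydrogen in place of methoxy on this aromatic carbon, ortho to a methoxy group and meta to a large group, gives an at least 7.9-fold higher number from compound 2 to compound 4 (0.89 log units; beyond the scatter), so this is the first change here isolated in a single place, and the methoxy group at this position clearly counts in this assay. The step between compound 1 and compound 4 cannot be read because both compounds sit at the limit: the limit of > 128000 nM in this assay, at which 2 of the 4 values shown sit.

The compounds shown leave open whether methoxy itself is needed at this position or whether another group, such as ethoxy, an amine or a halogen, would serve as well. From the compounds shown here alone, how far compound 4 lies past the limit also stays open, so the step has no upper size.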